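Notes on the aminopyrimidine series: sulfamoyl to nitro

The source may report more compounds than this note shows. Statements on the series, on what has been measured and on what is new or still open speak of the compounds shown alone.

Within the data shown here, compound 3 `CCn1nc(-c2ccnc(Nc3cccc(S(N)(=O)=O)c3)n2)c2ccccc21` gives 7260 nM in a functional assay on MCF7 cells (Homo sapiens) for antiproliferative activity, read by MTT assay, with a stated time of 72 h (a higher number here means a weaker inhibitor of growth, a lower number a stronger inhibitor of growth), the second highest of the three numbers so far. Its nearest neighbour is compound 2 `Cn1nc(-c2ccnc(Nc3cccc(S(N)(=O)=O)c3)n2)c2ccccc21`, which in this assay gives 2270 nM; the furthest is compound 1 `Clc1ccc(Nc2nc3ncccc3n2Cc2ccccc2)cc1`, which in this assay gives 48000 nM. Among the measured compounds shown here, the one step measured, a 3.2-fold higher number from compound 2 to compound 3 (0.50 log units; beyond the scatter), concerns the chain on the aromatic nitrogen and not the group on the aniline ring.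

Compound 4 `CCn1nc(-c2ccnc(Nc3cccc([N+](=O)[O-])c3)n2)c2ccccc21` differs from compound 3 by nitro in place of sulfamoyl on an aromatic carbon. For the measured compounds named here, no measured step bears on this exchange: compounds 2 and 3 both carry the sulfamoyl, and compound 1 carries a different core altogether. The expectation therefore rests on the size of the change alone, and a step beyond the scatter toward a higher number in this assay is expected, of the order of a 2.5-fold higher number from compound 3 to compound 4 (0.39 log units; beyond the scatter). For compound 4 the estimated value in this assay is 18000 nM, within a range from 5000 nM to 60000 nM.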

Compound 4, concentration for 50% growth inhibition: 2310 nM
Compound 4: the middle estimate sits 7.8-fold (0.89 log units) above what was measured, and the stated range ends above it.
By their numbers in this assay, from the lowest: compounds 2 and 4 (each within the scatter of the next); then compound 3; then compound 1.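

Among these compounds, at this position, on an aromatic carbon of the six-membered ring of carbon only, the earlier compounds held the sulfamoyl fixed; with the ethyl chain in place, in this assay the exchange gives a 3.1-fold lower number from compound 3 to compound 4 (0.50 log units; beyond the scatter). Nitro carries no hydrogen-bond donor, so growth inhibition at this level in compound 4 does not depend on the sulfamoyl or on a donor at this position, and the change runs toward stronger inhibition of growth, beyond the scatter. No measurement at hand accounts for the size or direction of this step.

Going by these compounds, whether nitro in place of sulfamoyl gives a step of like size with the methyl chain of compound 2 remains open. So does the standing of an amine, a carboxylic acid or a nitrile at this position.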